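Shifting the Methyl Around the Pyridinyl Ring

A few compounds are considered here, and "the series" means these few. Any claim that something is new, unique, unknown or untested is made for them only; others in the source may bear on it.

Compound 2 `Cc1ccnc(-c2cnc(C(=O)CCCCCCc3ccccc3)o2)c1` gives 0.6 nM in an assay (Rattus norvegicus) for inhibition of Fatty-acid amide hydrolase 1 (Homo sapiens) (on this read-out lower numbers stand for stronger inhibition and higher numbers for weaker inhibition), and stands lowest of the two measured numbers; compound 1 `O=C(CCCCCCc1ccccc1)c1ncc(-c2cccc(O)c2)o1` gives 50 nM in this assay, and the step of an 83-fold lower number from compound 1 to compound 2 (1.92 log units; beyond the scatter) is large. Compound 3 `Cc1ccc(-c2cnc(C(=O)CCCCCCc3ccccc3)o2)nc1` differs from compound 2 only in that (5-methylpyridin-2-yl in place of 4-methylpyridin-2-yl on an aromatic carbon). Going by the values given here, no measured step bears directly on moving the methyl within the pyridinyl group; the single recorded step exchanged the whole aryl group. The account therefore expects no change beyond the scatter, a step of a 1.7-fold higher number from compound 2 to compound 3 (0.22 log units; within the scatter). Compound 3 is estimated at 1 nM, within a range of 0.3 nM to 3.5 nM.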

Compound 3, inhibition constant: 2.8 nM
Compound 3: the middle estimate sits 2.8-fold (0.45 log units) below what was measured; the range from low to high includes it.
By their numbers in this assay, from the lowest: compound 2; then compound 3; then compound 1.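

Moving the methyl, with the same atoms joined differently, is enough to shift the number (a 4.7-fold higher number from compound 2 to compound 3 (0.67 log units; beyond the scatter)), so the 4-methylpyridin-2-yl and 5-methylpyridin-2-yl groups are not interchangeable here. The 5-methylpyridin-2-yl group still keeps a large advantage over 3-hydroxyphenyl (an 18-fold lower number from compound 1 to compound 3 (1.25 log units; beyond the scatter)). Nothing at hand explains why the placement of the methyl matters. The compounds shown leave open whether a methoxy group or a chlorine in place of the methyl, or a pyridin-2-yl group with no methyl at all, would match compound 2.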